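Swapping an Aryl Arm for a Heptyl Chain

The source may report more compounds than this note shows. Statements on the series, on what has been measured and on what is new or still open speak of the compounds shown alone.

Three compounds share one spiro core and differ only in the group on the ring nitrogen. Compound 1 `COC1Cc2sccc2C2(CCN(CCCCc3ccccc3)CC2)O1` gives 7.7 nM in an assay on membranes from brain for displacement of a labelled ligand from Sigma non-opioid intracellular receptor 1 (Cavia porcellus); on this read-out higher numbers stand for weaker inhibition and lower numbers for stronger inhibition. Compound 2 `COc1ccc(CN2CCC3(CC2)OC(OC)Cc2sccc23)cc1` gives 2.2 nM in this assay, and compound 3 `COC1Cc2sccc2C2(CCN(Cc3ccc(F)cc3)CC2)O1` gives 0.62 nM. Among the measured compounds shown here, compound 3 therefore stands at the lowest number of the three; its nearest neighbour is compound 2, and the one measured step, a 3.5-fold lower number from compound 2 to compound 3 (0.55 log units; beyond the scatter), is the only change recorded so far. Compound 1 lies furthest from it.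

Compound 4 `CCCCCCCCN1CCC2(CC1)OC(OC)Cc1sccc12` is the unmeasured case. Its change from compound 3 is heptyl in place of 4-fluorophenyl on a saturated chain carbon bound to an amine nitrogen in a ring. No recorded step concerns this kind of change: the one step shown exchanges one substituent on the aromatic ring for another, while here the aromatic ring itself leaves and a plain chain enters. Compound 1, which also carries no aromatic group directly on the chain carbon bound to the nitrogen but a longer link to its ring, shows a higher number than compound 3, and that is the only loose hint available. The expectation is therefore a moderate rise, a 6.5-fold higher number from compound 3 to compound 4 (0.81 log units; beyond the scatter), with wide uncertainty. Compound 4 is estimated at 4 nM, within 1.2 nM to 15 nM.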

Compound 4, inhibition constant: 5.1 nM
Beside the measured number, compound 4's estimate is 1.3-fold (0.11 log units) below it; low and high end bracket the measured number.
By their numbers in this assay, from the lowest: compound 3; then compound 2; then compounds 4 and 1 (each within the scatter of the next).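

In this assay the ring on the nitrogen substituent proves not to be essential, although the plain chain does give up ground to both aryl arms, with an 8.2-fold higher number from compound 3 to compound 4 (0.92 log units; beyond the scatter) and a 2.3-fold higher number from compound 2 to compound 4 (0.37 log units; beyond the scatter) as the two measured costs. Set against the longer phenyl-ended substituent of compound 1, the same chain shows a 1.5-fold lower number from compound 1 to compound 4 (0.18 log units; within the scatter), so in this pair a butyl end and a phenyl end on the chain cannot be told apart. Nothing shown explains why the aryl arms give the lower numbers in this series, and no supporting measurement bears on the heptyl change.

The compounds shown leave open how the number depends on chain length, since a butyl or a decyl chain on the ring nitrogen could sit on either side of the heptyl result. They also leave open whether the heptyl chain tolerates a hydroxyl group or an amine at its far end, and whether a cyclohexylmethyl group, which keeps a ring without aromatic character, would fall nearer compound 3 or compound 4.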